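The source may hold more compounds than are shown below. What is called first, only, known or untested is meant among the compounds shown, and "the series" means these compounds.

Three compounds share a core of compound 1 built from a cyclic sulfonyl imide joined through a linker to a piperazine that carries an aromatic group. Compound 1 `COc1ccccc1N1CCN(Cc2ccc(CN3C(=O)c4ccccc4S3(=O)=O)cc2)CC1` gives 97 nM in an assay on HEK293 cells for displacement of a labelled ligand from 5-hydroxytryptamine receptor 7 (Homo sapiens); a higher number here means a weaker inhibitor, a lower number a stronger inhibitor. Compound 2 `O=C1c2ccccc2S(=O)(=O)N1CCCCCN1CCN(c2ccccc2)CC1` gives 148 nM in this assay, and compound 3 `COc1ccccc1N1CCN(CCCCCCN2C(=O)c3ccccc3S2(=O)=O)CC1` gives 105 nM in this assay. Compound 2 shows the highest of the three numbers, but its gap to compound 3 and its gap to compound 1 both lie within the usual scatter, so the three compounds cannot be ranked against one another on these data.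

Compound 4 `O=C1c2ccccc2S(=O)(=O)N1CCCCCN1CCN(c2ncccn2)CC1` has not yet been measured. It differs from compound 2 in one place: pyrimidin-2-yl in place of phenyl on an amine nitrogen in a ring. Among the measured compounds shown here, no pair of measured compounds differing in a single place is available, so nothing here shows how this kind of exchange moves the number. The expectation for compound 4 is therefore a cautious one: a step of a 1.7-fold higher number from compound 2 to compound 4 (0.23 log units; within the scatter) is expected, toward a somewhat higher number, possibly beyond the scatter but not large. Compound 4 is expected to give 250 nM in this assay, with a range from 80 nM to 800 nM.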

Compound 4, inhibition constant: 2670 nM
Compound 4: middle estimate off by 11-fold (1.03 log units), on the low side, outside the stated range (above it).
By their numbers in this assay, from the lowest: compounds 1, 3 and 2 (each within the scatter of the next); then compound 4.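

Among the compounds shown here, the exchange of phenyl for pyrimidin-2-yl on an amine nitrogen in a ring gives an 18-fold higher number from compound 2 to compound 4 (1.26 log units; beyond the scatter) in this assay, the first step in this set between compounds that differ in one place and the first gap beyond the scatter. The result shows that this place is not indifferent to the identity of its aromatic ring: the leaving and entering groups both have 6 heavy atoms and one six-membered aromatic ring, yet the swap of ring carbon for ring nitrogen, which brings in 2 hydrogen-bond acceptors, goes with a large loss of strength in this pair. Nothing available here accounts for the size of the step.

From the compounds shown here alone, what remains open is whether a pyridin-2-yl group, with a single ring nitrogen, would give a number close to that of compound 2 or close to that of compound 4. For the compounds shown here, it is also open whether the same exchange would carry a step of this size on a different linker, such as the one in compound 1, since this single pair speaks only for the pentyl-linked compounds.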